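Swapping a Benzyl Group for a Branched Alkyl Chain

This account rests on a few compounds, and the source may have more. Where it says the series, first, only, none or still open, it means among the compounds named here.

Compound 1 `COc1ccc(-c2ccc3c(NCCCNCc4cccc(OC)c4O)ccnc3c2)cc1`: 1600 nM
Compound 2 `Cc1cc(C)cc(Cc2ccc3c(NCCCNCc4ccco4)ccnc3c2)c1`: 6270 nM
Compound 3 `COc1cccc(CNCCCNc2ccnc3cc(-c4ccc(F)cc4)ccc23)c1O`: 6840 nM

Of the compounds shown here, three have been measured in an ADME assay on HepG2 cells (Homo sapiens) for cytotoxicity, read by luminescence, CellTiter-Glo and ATP content, with a stated time of 72 h; on this read-out lower numbers stand for an effect already at smaller amounts and higher numbers for an effect only at larger amounts of compound. Compound 2 gives 6270 nM, the second highest of the three numbers; against compound 3 it lies within the scatter, while compound 1 sits clearly lower. Compound 4 `CCC(CC)c1ccc2c(NCCCNCc3ccco3)ccnc2c1` differs from compound 2 by pentan-3-yl in place of 3,5-dimethylbenzyl on an aromatic carbon. Going by the values given here, the only measured step, a 4.3-fold higher number from compound 1 to compound 3 (0.63 log units; beyond the scatter), concerns a different position and a different kind of exchange, so no measured step bears directly on this change. With nothing in the data pointing one way, the expected step of a 1.3-fold higher number from compound 2 to compound 4 (0.11 log units; within the scatter) is small and may well stay within the scatter. Compound 4 is therefore estimated at 8000 nM, within a range from 3000 nM to 20000 nM.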

Compound 4, half-maximal effective concentration: 6760 nM
For compound 4 the middle estimate is 1.2-fold (0.07 log units) above the measured one, within the range that was stated.
By their numbers in this assay, from the lowest: compound 1; then compounds 2, 4 and 3 (each within the scatter of the next).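

In this assay, putting pentan-3-yl in place of 3,5-dimethylbenzyl gives a 1.1-fold higher number from compound 2 to compound 4 (0.03 log units; within the scatter). At this position, then, the six-membered aromatic ring can go and the group can shrink from 9 to 5 heavy atoms without moving the number beyond the scatter. Nothing measured here explains why these two groups read alike. Still open, as far as these compounds go, is whether a much smaller carbon group such as methyl, or a group carrying an amine or a carboxylic acid, would leave the number just as undisturbed on this aromatic carbon.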